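Swapping hydroxy for amino on two related cores

The source may report more compounds than this note shows. Statements on the series, on what has been measured and on what is new or still open speak of the compounds shown alone.

Four compounds share a pattern of a ketone between two aromatic rings and a short amide side chain. Compound 1 `COc1ccc(C(=O)c2ccc(OC)c3c2OC(C)(C)C=C3)c(NC(=O)CO)c1` and compound 2 `COc1ccc(C(=O)c2ccc(OC)c3c2C=CC(C)(C)O3)c(NC(=O)CO)c1` have the same atoms joined differently; the difference between the two cores is not broken down here. Compound 3 `COc1ccc(C(=O)c2ccc(OC)c3c2OC(C)(C)C=C3)c(NC(=O)CN)c1` matches compound 1 except for the change (amino in place of hydroxy on a saturated chain carbon bound to a carbonyl carbon), and compound 4 `COc1ccc(C(=O)c2ccc(OC)c3c2C=CC(C)(C)O3)c(NC(=O)CN)c1` relates to compound 2 in the same way, through the change (amino in place of hydroxy on a saturated chain carbon bound to a carbonyl carbon). In a functional assay on A549 cells (Homo sapiens) for antiproliferative activity, read by MTT assay, with a stated time of 48 h (on this read-out lower numbers stand for stronger inhibition and higher numbers for weaker inhibition), compound 1 gives 80 nM, compound 2 gives 100 nM and compound 3 gives 270 nM. The values of compound 1 and compound 2 lie within the usual scatter of each other. Within the data shown here, the one measured step of this change is a 3.4-fold higher number from compound 1 to compound 3 (0.53 log units; beyond the scatter). Since the change and its place are the same, and compound 2 sits close to compound 1, a similar step is expected from compound 2 to compound 4 in this assay, namely a 3.4-fold higher number from compound 2 to compound 4 (0.53 log units; beyond the scatter). On that basis compound 4 is expected to give about 340 nM in this assay. The range for compound 4 is estimated at 170 nM to 700 nM.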

Compound 4, half-maximal inhibitory concentration: 420 nM
Compound 4: the middle estimate sits 1.2-fold (0.09 log units) below what was measured; low and high end bracket the measured number.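

Putting amino in place of hydroxy weakens the result on the second core as well in this assay, with a 4.2-fold higher number from compound 2 to compound 4 (0.62 log units; beyond the scatter) on that core. Set beside the earlier step, the change carries over between these two cores at much the same size, and the two steps cannot be told apart: the same change on two cores in this assay, a 3.4-fold higher number (0.53 log units; beyond the scatter) from compound 1 to compound 3 and a 4.2-fold higher number (0.62 log units; beyond the scatter) from compound 2 to compound 4, 1.2-fold (0.09 log units) apart, within the scatter of two such steps. Among these compounds, this rests on only two pairs of compounds on two closely related cores in one cell assay, so it does not show that the change would behave the same way on any other core or in other cells, and it does not explain why the amino compounds give higher numbers.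

The compounds shown leave open what other groups would do in the same place, on the saturated chain carbon bound to a carbonyl carbon, such as a dimethylamino group, a methoxy group or a carboxylic acid. They also leave open whether a longer chain carrying the hydroxy or the amino would follow the same trend.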